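A few compounds are considered here, and "the series" means these few. Any claim that something is new, unique, unknown or untested is made for them only; others in the source may bear on it.

Going by the values given here, in a functional assay on HepG2 cells (Homo sapiens) for antiproliferative activity, read by CCK-8 assay, with a stated time of 72 h (a lower number here means a stronger inhibitor, a higher number a weaker inhibitor), compound 1 `Nc1ccccc1NC(=O)c1ccc(Cn2cnc3c(NCc4ccccc4)nc(Cl)nc32)cc1` gives 7720 nM as the lower of the two numbers so far, and compound 2 `Nc1ccccc1NC(=O)c1ccc(Cn2cnc3c(Nc4ccc(-c5ccccn5)cc4)nc(Cl)nc32)cc1` stands higher at 30100 nM on the same scale. Compound 3 `CN1CCN(c2nc(Cl)nc3c2ncn3Cc2ccc(C(=O)Nc3ccccc3N)cc2)CC1` carries 4-methylpiperazin-1-yl in place of benzylamino on an aromatic carbon. Among the compounds with values here, only one measured step bears on this place, a 3.9-fold higher number from compound 1 to compound 2 (0.59 log units; beyond the scatter) for 4-(pyridin-2-yl)phenyl in place of benzyl, which is modest but beyond the scatter. A similar modest rise is therefore expected in this assay for this change (a 1.8-fold higher number from compound 1 to compound 3 (0.26 log units; within the scatter)). Compound 3 is estimated at 14000 nM with an expected range from 4000 nM to 45000 nM overall.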

Compound 3, half-maximal inhibitory concentration: 2010 nM
Estimate against measurement, compound 3: 7.0-fold (0.84 log units) above; the measured number lies below the stated range.
By their numbers in this assay, from the lowest: compound 3; then compound 1; then compound 2.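

In this assay, going by these compounds alone, the step of a 3.8-fold lower number from compound 1 to compound 3 (0.58 log units; beyond the scatter) goes with 4-methylpiperazin-1-yl in place of benzylamino, opposite in direction to the only earlier change at this place. This aromatic carbon next to the ring nitrogen can therefore move the number either way, and a saturated ring without a hydrogen-bond donor is accepted here. No measured property is available to explain this difference.

The compounds shown leave open whether the methyl on the piperazine matters, and whether morpholine or an open-chain dimethylamino group would behave like 4-methylpiperazin-1-yl.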